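Aryl replacement on the shared core of compound 1

The source may hold more compounds than are shown below. What is called first, only, known or untested is meant among the compounds shown, and "the series" means these compounds.

Compound 1 `COC(=O)c1sc2cc(-c3cccs3)cnc2c1N` sits at the weak end of the numbers shown. In a functional assay on A-375 cells (Homo sapiens) for inhibition, read by sulforhodamine B assay, with a stated time of 48 h (on this read-out lower numbers stand for stronger inhibition of growth and higher numbers for weaker inhibition of growth), compound 1 gives > 150000 nM, which is a limit of the assay and not a number. Compound 2 `COC(=O)c1sc2cc(-c3ccc(-c4cccs4)s3)cnc2c1N` carries thiophen-2-yl in place of hydrogen on an aromatic carbon, and in this assay compound 2 gives > 75000 nM, again a limit. Compound 1 rests at the limit of > 150000 nM in this assay, at which 1 of the 3 values shown sits, and compound 2 at the limit of > 75000 nM in this assay, at which 1 of the 3 values shown sits, so the step that the two limits leave unreadable from compound 1 to compound 2 cannot be read. For the measured compounds named here, compound 3 `COC(=O)c1sc2cc(-c3ccc4ccccc4c3)cnc2c1N` is the only member with a measured number: in this assay compound 3 gives 95600 nM.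

Compound 4 `COC(=O)c1sc2cc(-c3cccc(N)c3)cnc2c1N` differs from compound 1 by 3-aminophenyl in place of thiophen-2-yl on an aromatic carbon. Going by the values given here, no measured step bears on this change; the single step is unreadable, and compound 3 shows only that a different aryl group at this position yields a weak but readable number. Compound 4 is therefore expected near the upper edge of the measurable range, estimated at 90000 nM with a range from 25000 nM to 300000 nM. The step implied by this estimate, an at least 1.6-fold lower number from compound 1 to compound 4 (0.22 log units; that floor lies within the scatter), is expected to be small and may not be readable against a limit.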

Compound 4, concentration for 50% growth inhibition: > 150000 nM
Compound 4 was reported as a limit; the forecaster's own chance of this, stated with the estimate: 50%; middle value at least 1.6-fold (0.22 log units) away from the limit.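

Compound 4 stands at a limit of the assay and not a number, the same limit as compound 1: the limit of > 150000 nM in this assay, at which 2 of the 4 values shown sit. The step between compound 1 and compound 4 therefore cannot be read. The compounds shown leave open how 3-aminophenyl and thiophen-2-yl compare at this place in this assay on the shared core.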